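The compounds below may be only part of what the source reports. "The series", "measured", "known", "first", "only" and "open" are said of these compounds alone.

Compound 1 `O=C(CC(c1c(Cl)cccc1Cl)c1c[nH]c2ccccc12)c1c(O)c2ccccc2oc1=O`: 13.5 ug/mL
Compound 2 `COc1ccc(OC)c(C(CC(=O)c2c(O)c3ccccc3oc2=O)c2c[nH]c3ccccc23)c1`: 19 ug/mL

These two compounds have been measured in a physicochemical assay, read by spectrophotometry, with a stated time of 30 min; on this read-out higher numbers stand for weaker inhibition and lower numbers for stronger inhibition. There, compound 2 gives 19 ug/mL, which lies within the usual scatter of compound 1 at 13.5 ug/mL. The two numbers therefore cannot be ranked. The next compound, compound 3 `O=C(CC(c1ccc(O)cc1)c1c[nH]c2ccccc12)c1c(O)c2ccccc2oc1=O`, is not yet measured. It has 4-hydroxyphenyl in place of 2,5-dimethoxyphenyl on a saturated chain carbon bound to an aromatic carbon and a saturated chain carbon.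

For the measured compounds named here, only one measured step bears on this change, as it swaps the group on that same carbon: a 1.4-fold higher number from compound 1 to compound 2 (0.15 log units; within the scatter). Going by the values given here, that step is small, but it is a single example, and no measured compound carries 4-hydroxyphenyl. No shift beyond the scatter is therefore expected in this assay. The expected step is a 1.2-fold lower number from compound 2 to compound 3 (0.07 log units; within the scatter). For compound 3 the estimated value is 16 ug/mL, with an expected range of 7 ug/mL to 35 ug/mL.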

Compound 3, half-maximal inhibitory concentration: 58.9 ug/mL
For compound 3 the middle estimate is 3.7-fold (0.57 log units) below the measured one, and the stated range ends below it.
By their numbers in this assay, from the lowest: compounds 1 and 2 (each within the scatter of the next); then compound 3.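

In this assay, the group on this saturated chain carbon can clearly shift the number, which the earlier swap, lying within the scatter, did not show. Placing 4-hydroxyphenyl there gives a 3.1-fold higher number from compound 2 to compound 3 (0.49 log units; beyond the scatter) and a 4.4-fold higher number from compound 1 to compound 3 (0.64 log units; beyond the scatter) so it stands apart from both 2,5-dimethoxyphenyl and 2,6-dichlorophenyl, with weaker inhibition than either. Compared with 2,5-dimethoxyphenyl, it has fewer heavy atoms and brings a hydrogen-bond donor, but nothing available shows which of these differences, if either, accounts for the shift.

As far as these compounds go, what a plain phenyl or a 4-methoxyphenyl would give on this carbon remains open, and so does whether the hydroxyl itself matters or only the loss of the two methoxy groups. An amine in the same spot would test whether other groups behave like this hydroxyl.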